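The source may report more compounds than this note shows. Statements on the series, on what has been measured and on what is new or still open speak of the compounds shown alone.

Measured so far in a functional assay on HeLa cells (Homo sapiens) for antiproliferative activity; a higher number here means a weaker inhibitor, a lower number a stronger inhibitor:
compound 1, `Cc1cc2c(F)c(Oc3ncnc(N)c3/C=N/OCCO)ccc2[nH]1`, gives 406 nM
compound 2, `Cc1cc2c(F)c(Oc3ncnc(N)c3/C=N/OCC3CCCCC3)ccc2[nH]1`, gives 22700 nM
compound 3, `CO/N=C/c1c(N)ncnc1Oc1cc2cc[nH]c2cc1F`, gives 382 nM

Compound 1 stands second highest of the three numbers. Its nearest neighbour is compound 3, whose value lies within the scatter of that of compound 1, so the two are not told apart. Going by the values given here, its furthest is compound 2: a 56-fold higher number from compound 1 to compound 2 (1.75 log units; beyond the scatter), the one single-point step in the set and a large one.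

Compound 4, `Cc1cc2c(F)c(Oc3ncnc(N)c3/C=N/OCCCO)ccc2[nH]1`, differs from compound 1 by hydroxymethyl in place of hydroxy on a saturated chain carbon, two bonds along the chain from an oxygen. Read a bond further out, the chain on the oxygen goes from 2-hydroxyethoxy to 3-hydroxypropoxy; the hydroxy end of the chain is kept.

Among the compounds with values here, the only step at this place is the one from compound 1 to compound 2, where hydroxymethyl gave way to cyclohexyl and the number rose far beyond the scatter. Compound 4 keeps the hydroxy, so a shift of that kind is not expected. Within the data shown here, a lengthened chain with the same end has no precedent in the set, and the expected step is therefore small: a 1.4-fold higher number from compound 1 to compound 4 (0.13 log units; within the scatter), at most a slight rise, likely within the scatter. Compound 4 is estimated at 550 nM, with a range from 250 nM to 1300 nM.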

Compound 4, half-maximal inhibitory concentration: 362 nM
Compound 4: the middle estimate sits 1.5-fold (0.18 log units) above what was measured; low and high end bracket the measured number.
By their numbers in this assay, from the lowest: compounds 4, 3 and 1 (each within the scatter of the next); then compound 2.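

In this assay, going from 2-hydroxyethoxy to 3-hydroxypropoxy with the hydroxy end kept gives a 1.1-fold lower number from compound 1 to compound 4 (0.05 log units; within the scatter) and so leaves the two compounds untold apart, the first sign that this chain can take a change of length without a measurable shift. Set against the cyclohexyl-ended chain, the new compound gives a 63-fold lower number from compound 2 to compound 4 (1.80 log units; beyond the scatter) and thus repeats the large gap of a 56-fold higher number from compound 1 to compound 2 (1.75 log units; beyond the scatter) from a second hydroxy-ended chain, so the separation of compound 2 no longer rests on compound 1 alone. No evidence on the reason for either result is at hand.

The compounds shown do not separate the loss of the hydroxy end from the arrival of the cyclohexyl ring, a question that a plain hexyl chain or a methoxy-ended chain of similar length would address. Going by these compounds, how far the tolerance for length extends also stays open, as does whether it survives a longer chain such as 4-hydroxybutoxy or a terminal amine or carboxylic acid in place of the hydroxy.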